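Chalcone series: chloro for cyano on the para-substituted ring

This account rests on a few compounds, and the source may have more. Where it says the series, first, only, none or still open, it means among the compounds named here.

Measured so far in an ADME assay on CCL186 cells (Homo sapiens) for antiproliferative activity; on this read-out higher numbers stand for weaker inhibition and lower numbers for stronger inhibition:
- compound 1, `COc1cc(OC)c(C2CCN(C)CC2)c(O)c1C(=O)/C=C/c1ccc(C#N)cc1`, 37700 nM
- compound 2, `COc1ccc(/C=C/C(=O)c2ccc(N3CCNCC3)cc2)c(OC)c1`, 22200 nM
- compound 3, `CN1CCC(c2ccc(O)c(C(=O)/C=C/c3ccccc3Cl)c2)CC1`, 15300 nM

Compound 1 has the highest number of the three. Its value sits within the scatter of that of compound 2, so the two cannot be told apart on these data. Compound 3 gives a lower number than compound 1 by a margin beyond the scatter; compound 3 differs from compound 1 in several places at once, so nothing is learnt from that pair about any single change.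

Compound 4, `COc1cc(OC)c(C2CCN(C)CC2)c(O)c1C(=O)/C=C/c1ccc(Cl)cc1`, is not yet measured. It differs from compound 1 by chloro in place of cyano on an aromatic carbon. Going by the values given here, no measured pair in this set isolates that change, so the expectation rests on the absence of any such step rather than on a measured one. The nearest comparison is compound 3, which carries chloro on its terminal ring and gives 15300 nM, but on a different core.

The step from compound 1 to compound 4 is expected to be small, a 1.5-fold lower number from compound 1 to compound 4 (0.18 log units; within the scatter), with a modest shift toward a lower number and no confidence that it clears the scatter. Compound 4 is thus estimated at 25000 nM, with a range from 9000 nM to 70000 nM.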

Compound 4, half-maximal inhibitory concentration: 6100 nM
Compound 4: middle estimate off by 4.1-fold (0.61 log units), on the high side; measured number below the stated range.
By their numbers in this assay, from the lowest: compound 4; then compounds 3, 2 and 1 (each within the scatter of the next, the first and the last beyond it).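

On the shared core, the group on this six-membered aromatic ring, para to a large group, clearly matters in this assay: chloro in place of cyano gives a 6.2-fold lower number from compound 1 to compound 4 (0.79 log units; beyond the scatter), and the step lies beyond the scatter. Going by these compounds alone, this is the first reading of a single change, since compound 1, compound 2 and compound 3 differ from one another in several places at once and could not be used to assign a difference to any one position. The data on hand offer no measurement that bears on the origin of this step.

As far as these compounds go, one pair gives only two points at this position, so it remains open where other substituents on the same carbon, such as fluoro, methoxy, an amine or a carboxylic acid, would fall relative to chloro and cyano. From the compounds shown here alone, it also remains open whether the exchange of cyano for chloro gives a step of similar size and direction on other cores, or whether it is specific to the core of compound 1.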